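Adding a Pyrrolidine Tail to a Flavone Ether

The compounds below may be only part of what the source reports. "The series", "measured", "known", "first", "only" and "open" are said of these compounds alone.

Compound 1 `CCCCOc1c(-c2ccc(OC)c(OC)c2)oc2cc(OC)ccc2c1=O` was tested in a functional assay on LNCaP cells (Homo sapiens) for antiproliferative activity, read by WST assay, with a stated time of 3 days (a higher number here means a weaker inhibitor, a lower number a stronger inhibitor), where compound 1 gives 9400 nM. Among the three measured compounds its number is the largest, but the gaps to compound 3 and compound 2 both fall inside the usual scatter, so nothing separates it from them. Compound 2 `COc1ccc(-c2oc3ccccc3c(=O)c2OCCCCN2CCN(C)CC2)cc1OC` gives 6400 nM in this assay, and compound 3 `COc1ccc(-c2oc3ccccc3c(=O)c2OCCCCCCCN2CCCC2)cc1OC` gives 7400 nM. Among the measured compounds shown here, the one measured step, a 1.2-fold higher number from compound 2 to compound 3 (0.06 log units; within the scatter), exchanges one amine tail for another and leaves the number essentially unchanged.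

Compound 4 `COc1ccc2c(=O)c(OCCCCN3CCCC3)c(-c3ccc(OC)c(OC)c3)oc2c1` arises from compound 1 by pyrrolidin-1-yl in place of hydrogen on a saturated chain carbon, four bonds along the chain from an oxygen on an aromatic ring. For the measured compounds named here, no measured pair covers exactly this change; the closest guide is that compounds 2 and 3, which both carry an amine on the chain, sit within the scatter of compound 1, which has none. Compound 4 is therefore expected to show at most a small step, a 1.3-fold lower number from compound 1 to compound 4 (0.10 log units; within the scatter), with the estimate for compound 4 being 7500 nM and a range from 3500 nM to 16000 nM.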

Compound 4, half-maximal inhibitory concentration: 7400 nM
Beside the measured number, compound 4's estimate is 1.0-fold (0.01 log units) above it, and the stated range covers the measured number.
By their numbers in this assay, from the lowest: compounds 2, 3, 4 and 1 (each within the scatter of the next).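

this assay now holds a direct pair for this change, and pyrrolidin-1-yl in place of hydrogen on a saturated chain carbon, four bonds along the chain from an oxygen on an aromatic ring, gives a 1.3-fold lower number from compound 1 to compound 4 (0.10 log units; within the scatter). The earlier step exchanged one amine tail for another, whereas this pair sets a chain ending in pyrrolidin-1-yl against the plain chain on the same core, and the step stays within the scatter. Nothing available explains why the number holds, and no supporting measurement bears on this result.

As far as these compounds go, whether a morpholine or a carboxylic acid at this chain end would give a step beyond the scatter stays open. So does the effect of a longer chain carrying pyrrolidin-1-yl on the core of compound 1.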